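Isopropyl replaces the dimethylcarbamoylmethyl chain on compound 3

The source may hold more compounds than are shown below. What is called first, only, known or untested is meant among the compounds shown, and "the series" means these compounds.

Compound 1 `Cn1cc(-c2ccc(NC(=O)c3cn(CC4CCCCC4)cc(-c4ccc(F)cc4)c3=O)cc2)c2c(N)ncnc21`: 2.3 nM
Compound 2 `COCCCn1cc(C(=O)Nc2ccc(-c3cn(C)c4ncnc(N)c34)cc2)c(=O)c(-c2ccc(F)cc2)c1`: > 10 nM
Compound 3 `CN(C)C(=O)Cn1cc(C(=O)Nc2ccc(-c3cn(C)c4ncnc(N)c34)cc2)c(=O)c(-c2ccc(F)cc2)c1`: 0.5 nM

In an assay on isolated protein for inhibition of tyrosine-protein kinase receptor UFO (Homo sapiens), read by ELISA (a higher number here means a weaker inhibitor, a lower number a stronger inhibitor), compound 3 holds the lowest of the two numbers; compound 1 comes nearest, and the value of compound 2 is a limit of the assay rather than a number. Compound 4 `CC(C)n1cc(C(=O)Nc2ccc(-c3cn(C)c4ncnc(N)c34)cc2)c(=O)c(-c2ccc(F)cc2)c1` differs from compound 3 in one place: isopropyl in place of (dimethylcarbamoyl)methyl on an aromatic nitrogen. Among the measured compounds shown here, two measured steps bear on this change, both leading into the dimethylcarbamoyl group: a 4.6-fold lower number from compound 1 to compound 3 (0.66 log units; beyond the scatter) and an at least 20-fold lower number from compound 2 to compound 3 (1.30 log units; beyond the scatter). Going the other way, from that group to a plain alkyl chain, compound 4 is therefore expected to give a higher number in this assay, a modest step, a 6.0-fold higher number from compound 3 to compound 4 (0.78 log units; beyond the scatter). The estimate for compound 4 is 3 nM, within 1 nM to 10 nM.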

Compound 4, half-maximal inhibitory concentration: 0.4 nM
Compound 4: the middle estimate sits 7.5-fold (0.88 log units) above what was measured; the whole stated range lies above it.
By their numbers in this assay, from the lowest: compounds 4 and 3 (each within the scatter of the next); then compound 1. At a limit, above all of these: compound 2.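

The step of a 1.3-fold lower number from compound 3 to compound 4 (0.10 log units; within the scatter) shows that this aromatic nitrogen can carry isopropyl, with no hydrogen-bond acceptor, and still keep a number level with that of the (dimethylcarbamoyl)methyl chain. Plain carbon groups are not all alike here, since a 5.8-fold lower number from compound 1 to compound 4 (0.76 log units; beyond the scatter) sets isopropyl apart from cyclohexylmethyl, while an at least 25-fold lower number from compound 2 to compound 4 (1.39 log units; beyond the scatter) sets it apart from 3-methoxypropyl. The second of these steps rests on compound 2, whose value is a limit: the limit of > 10 nM in this assay, at which 1 of the 4 values shown sits.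

As far as these compounds go, whether methyl, an amine or a carboxylic acid on this nitrogen would keep so low a number stays open.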